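Methylating the pyrazole nitrogen of compound 3

This account rests on a few compounds, and the source may have more. Where it says the series, first, only, none or still open, it means among the compounds named here.

Of the compounds shown here, three with a shared core have been tested in an in vitro functional assay on cells (Fibroblast) for agonist activity at Alpha-1A adrenergic receptor (Homo sapiens); on this read-out lower numbers stand for an effect already at smaller amounts and higher numbers for an effect only at larger amounts of compound. Compound 1 `Cn1ncnc1-c1ccccc1NCC1=NCCN1` gives 2 nM. Compound 2 `Cc1n[nH]c(-c2ccccc2NCC2=NCCN2)n1` gives 794 nM, and the change amounts to a 400-fold higher number from compound 1 to compound 2 (2.60 log units; beyond the scatter). Compound 3 `c1ccc(-c2cn[nH]c2)c(NCC2=NCCN2)c1` gives 1.26 nM, which is the lowest of the three numbers; its step from compound 1 is a 1.6-fold lower number from compound 1 to compound 3 (0.20 log units; within the scatter), while from compound 2 it is a 630-fold lower number from compound 2 to compound 3 (2.80 log units; beyond the scatter).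

Compound 4 `Cn1cc(-c2ccccc2NCC2=NCCN2)cn1` has not yet been measured. It differs from compound 3 by methyl in place of hydrogen on an aromatic nitrogen. Among the measured compounds shown here, none of the measured steps adds a methyl to a ring nitrogen alone; each exchanges one whole aromatic ring for another. The closest guidance is that compound 1, whose azole carries a methyl on a ring nitrogen, and compound 3, whose azole carries none, stand within the scatter of each other in this assay, whereas the ring exchange from compound 1 to compound 2 is large. On this basis the step from compound 3 to compound 4 is expected to be small in this assay, a 2.0-fold higher number from compound 3 to compound 4 (0.30 log units; within the scatter), with no direction beyond the scatter. Compound 4 is therefore estimated at 2.5 nM, within a range from 0.8 nM to 8 nM.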

Compound 4, half-maximal effective concentration: 398 nM
For compound 4 the middle estimate is 160-fold (2.20 log units) below the measured one; the measured number lies above the stated range.
By their numbers in this assay, from the lowest: compounds 3 and 1 (each within the scatter of the next); then compounds 4 and 2 (each within the scatter of the next).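

In this assay, the aromatic nitrogen of the pyrazole proves to be a sensitive position: a single methyl in place of hydrogen there gives (a 320-fold higher number from compound 3 to compound 4 (2.50 log units; beyond the scatter)), a step among the large ones, although the earlier large steps each exchanged one whole aromatic ring for another. A methyl on a ring nitrogen does not set the number by itself, as both compound 1 and compound 4 carry one, yet 1-methyl-1H-pyrazol-4-yl in place of 1-methyl-1H-1,2,4-triazol-5-yl gives (a 200-fold higher number from compound 1 to compound 4 (2.30 log units; beyond the scatter)), so the effect of this methyl depends on the ring that bears it. Compound 4 instead falls with compound 2 (a 2.0-fold lower number from compound 2 to compound 4 (0.30 log units; within the scatter)), which shows that two different azoles, each with one methyl, can both end far from compound 1 and compound 3.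

The compounds shown leave open whether the change depends on methyl itself or on any group at this nitrogen, such as ethyl, acetyl or 2-hydroxyethyl, and what a methyl on a ring carbon of the pyrazole would do. Nothing available here explains the size of this step.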